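This account rests on a few compounds, and the source may have more. Where it says the series, first, only, none or still open, it means among the compounds named here.

The compounds share the core of compound 1 `COc1ccc2[nH]c(C(=O)N3CC(=O)N(Cc4ccccc4)[C@@H](CCc4ccccc4)C3)cc2c1`, with an amide-bearing ring carrying a benzyl group and, on a saturated chain carbon bound to a saturated ring carbon, a group that varies. In a physicochemical assay for solubility, read by spectrophotometry, in phosphate buffer, with a stated time of 2 h, at pH 7.4 (on this read-out higher numbers stand for higher solubility and lower numbers for lower solubility), compound 1 gives 4400 nM. Compound 2 `COc1ccc2[nH]c(C(=O)N3CC(=O)N(Cc4ccccc4)[C@@H](CN4CCCC4)C3)cc2c1` carries pyrrolidin-1-yl in that place; in this assay compound 2 reaches only a limit, > 25000 nM. Compound 3 `COc1ccc2[nH]c(C(=O)N3CC(=O)N(Cc4ccccc4)[C@@H](CN4[C@H](C)COC[C@@H]4C)C3)cc2c1` carries 3,5-dimethylmorpholin-4-yl; in this assay compound 3 likewise reaches only a limit, > 100000 nM. On the numbers shown, compound 3 stands at the top, since an at least 22-fold higher number from compound 1 to compound 3 (1.35 log units; beyond the scatter), and an at least 5.6-fold higher number from compound 1 to compound 2 (0.75 log units; beyond the scatter); the step that the two limits leave unreadable from compound 2 to compound 3 cannot be sized, as both values sit at limits, the limit of > 100000 nM in this assay, at which 1 of the 3 values shown sits, and (the limit of > 25000 nM in this assay, at which 1 of the 3 values shown sits).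

Going by the values given here, compound 4 `COc1ccc2[nH]c(C(=O)N3CC(=O)N(Cc4ccccc4)[C@@H](CN4CCCc5ccccc54)C3)cc2c1` is not yet measured in this assay. 1,2,3,4-tetrahydroquinolin-1-yl in place of 3,5-dimethylmorpholin-4-yl on a saturated chain carbon bound to a saturated ring carbon Of the measured steps, the one from compound 1 to compound 3 bears most directly on it. The entering group, like the benzyl of compound 1, contains a six-membered aromatic ring of carbon only, and that step was large. A step back in the opposite direction is therefore expected, estimated as an at least 28-fold lower number from compound 3 to compound 4 (1.45 log units; beyond the scatter), though its size is uncertain because compound 3 sits at a limit. Compound 4 is expected to give about 3500 nM in this assay, within a range from 800 nM to 15000 nM.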

Compound 4, solubility: 8500 nM
Compound 4: middle estimate off by 2.4-fold (0.39 log units), on the low side; the range from low to high includes it.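

In this assay a group holding a ring nitrogen at this place can still fall well short of the other two nitrogen-bearing groups, as the steps of an at least 11-fold lower number from compound 3 to compound 4 (1.07 log units; beyond the scatter) and an at least 2.9-fold lower number from compound 2 to compound 4 (0.46 log units; beyond the scatter) show. Nitrogen in the group is thus not enough on its own on this saturated chain carbon, and the comparison with benzyl gives a 1.9-fold higher number from compound 1 to compound 4 (0.29 log units; within the scatter) and so no real separation. The entering 1,2,3,4-tetrahydroquinolin-1-yl shares with benzyl a six-membered aromatic ring of carbon only, which pyrrolidin-1-yl and 3,5-dimethylmorpholin-4-yl lack, and across these four compounds the lower numbers go with that ring.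

Compound 2 and compound 3 both stand at limits, so the step between them cannot be read and the steps down from them give only minimum sizes. Going by these compounds, the change to compound 4 also replaces the whole ring at once, so it remains open whether a piperidin-1-yl, an unsubstituted morpholin-4-yl or a phenyl ring set further out on a longer chain would stand with compound 4 or with compound 3.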